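Branching the Amide Chain: Propyl Becomes Isopropyl

A few compounds are considered here, and "the series" means these few. Any claim that something is new, unique, unknown or untested is made for them only; others in the source may bear on it.

Three compounds built on a shared core have results so far. Compound 1 `CCN(Cc1ccccc1)C(=O)C1CCN(S(=O)(=O)c2c[nH]cn2)CC1` was entered in a functional assay on CHO cells for positive allosteric modulation of muscarinic acetylcholine receptor M5 (Homo sapiens), read by calcium flux (on this read-out lower numbers stand for smaller maximal responses and higher numbers for larger maximal responses), but gave "not determined" (no result reported). Compound 2 `CCN(C(=O)C1CCN(S(=O)(=O)c2ccc3c(c2)CCC3)CC1)[C@H](C)c1ccccc1` reached 97% in this assay. Compound 3 `CCCN(Cc1ccccc1C(F)(F)F)C(=O)C1CCN(S(=O)(=O)c2ccc3[nH]ncc3c2)CC1` reached 94% in this assay; these two numbers sit close together, within the scatter of each other, so neither stands apart. Compound 4 `CC(C)N(Cc1ccccc1C(F)(F)F)C(=O)C1CCN(S(=O)(=O)c2ccc3[nH]ncc3c2)CC1` awaits measurement. It differs from compound 3 in one place: isopropyl in place of propyl on an amide-type nitrogen. Within the data shown here, no measured pair differs at just this position, so no step size is known from the data. The expectation is a step of no change at the digits printed from compound 3 to compound 4 (within the scatter), meaning nothing beyond the scatter in this assay. Compound 4 is therefore estimated at 94%, within a range from 80% to 105%.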

Compound 4, largest response reached (reported as percent of maximum), in percent of the reference or control that the assay uses: 54%
For compound 4 the middle estimate is 40 percentage points above the measured one, and the stated range ends above it.
By their numbers in this assay, from the lowest: compound 4; then compounds 3 and 2 (each within the scatter of the next).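

Moving from propyl to isopropyl on an amide-type nitrogen keeps the same atoms, joined differently, yet in this assay it gives a number 40 percentage points lower from compound 3 to compound 4 (beyond the scatter). This pair shows that the maximal response at this position depends on how the chain is joined, and not only on how many carbons it holds. No measurement at hand accounts for this change. Still open, as far as these compounds go, is how the response would change with a cyclopropyl or tert-butyl group on the same nitrogen, and whether a straight butyl chain would behave like propyl.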